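A few compounds are considered here, and "the series" means these few. Any claim that something is new, unique, unknown or untested is made for them only; others in the source may bear on it.

Of the compounds shown here, three have been measured in an assay on isolated protein for activation of cGMP-dependent protein kinase 1 (Homo sapiens), read by ADP-Glo, with stated times of 30 min and 2 h, in the presence of a further agent that is not named here (a lower number here means that less compound is needed, a higher number that more compound is needed for the effect), and they differ from one another in more than one place at a time. Compound 1 `COC(=O)c1ccc(CN2CCC[C@H](O[C@H](CO)c3cc(Cl)cc(Cl)c3)[C@@H]2c2ccccc2)c(C)c1` gives 900 nM. Compound 2 `Cc1cc(C(=O)O)ccc1CN1CCC[C@H](O[C@H](CO)c2cc(Cl)cc(Cl)c2)[C@@H]1c1cccnc1` gives 47000 nM. Compound 3 `Cc1cc(C(=O)O)ccc1CN1CCC[C@H](O[C@H](CO)c2ccccc2)[C@@H]1c1ccccc1` gives 25000 nM. On these numbers compound 3 stands second highest of the three: its number and that of compound 2 lie within the usual scatter of each other, so no order between them can be read, while compound 1 sits well below it, a gap that is clearly beyond the scatter. Every pair of these compounds differs in several places. None of the gaps can be tied to a single change.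

Compound 4 `Cc1cc(C(=O)O)ccc1CN1CCC[C@H](O[C@H](CF)c2cc(Cl)cc(Cl)c2)[C@@H]1c1ccccc1` is not yet measured. It differs from compound 3 in one place: a group of 11 heavy atoms (8 carbon, 1 fluorine, 2 chlorine; one six-membered aromatic ring of carbon only) in place of a group of 9 heavy atoms (8 carbon, 1 oxygen; one six-membered aromatic ring of carbon only), on an oxygen on a saturated carbon. The hydroxyl group gives way to fluorine and the aromatic ring gains chlorine. Among the measured compounds shown here, since no single-change step is available, the expectation rests loosely on the whole set. Compound 4 is expected to give a somewhat lower number than compound 3, a step of a 2.5-fold lower number from compound 3 to compound 4 (0.40 log units; beyond the scatter), though with wide uncertainty. The estimate for compound 4 in this assay is 10000 nM, expected to fall between 2000 nM and 50000 nM.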

Compound 4, half-maximal effective concentration: 9100 nM
Compound 4: the middle estimate sits 1.1-fold (0.04 log units) above what was measured; the measured number falls inside the stated range.
By their numbers in this assay, from the lowest: compound 1; then compound 4; then compounds 3 and 2 (each within the scatter of the next).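

In this assay, replacing the 2-hydroxy-1-phenylethyl group, on an oxygen on a saturated carbon, with the group carrying fluorine and chlorine gives a 2.7-fold lower number from compound 3 to compound 4 (0.44 log units; beyond the scatter). Among the compounds shown here, this is the first step that can be tied to one place, and it shows that the number responds to a change there, modestly but beyond the usual scatter. That one place holds more than one alteration, however, since the hydroxyl gives way to fluorine, the aromatic ring gains chlorine, and the count of hydrogen-bond donors and acceptors in the group falls to zero, while nothing available here explains why the number moves.

From the compounds shown here alone, it remains open which alteration carries the step, since the fluorine and the chlorine atoms arrive together and only a compound with one of them alone could separate their contributions. Also open, going by these compounds, is how the number would respond to other replacements for the fluorine on this side chain, such as a methoxy group or an amine, and whether the step would keep its size on a different ring or with the methyl ester in place of the carboxylic acid.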